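The source may hold more compounds than are shown below. What is called first, only, known or untested is meant among the compounds shown, and "the series" means these compounds.

Of the compounds shown here, three sharing one core have been measured in an assay on membranes from Sf9 cells for displacement of a labelled ligand from histamine H2 receptor (Homo sapiens), read by scintillation counting, with a stated time of 60 min; a lower number here means a stronger inhibitor, a higher number a weaker inhibitor. Compound 1 `Cc1nc(N)sc1CCCN/C(N)=N/C(=O)NC1CCCCC1` gives 170 nM. Within the data shown here, compound 2 `Cc1nc(N)sc1CCCN/C(N)=N/C(=O)N[C@@H](C)c1ccccc1` gives 51.3 nM, and the single change between them, a 3.3-fold lower number from compound 1 to compound 2 (0.52 log units; beyond the scatter), is the only measured step in the set. Compound 3 `Cc1ccc(C(C)NC(=O)/N=C(\N)NCCCc2sc(N)nc2C)cc1` gives 30.9 nM, the lowest of the three numbers; the nearest is compound 2, and those two values sit within the scatter of each other, while compound 1 sits well beyond it.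

Compound 4 `Cc1nc(N)sc1CCCN/C(N)=N/C(=O)NC(C)c1ccco1` differs from compound 3 in one place: furan-2-yl in place of 4-methylphenyl on a saturated chain carbon bound to an amide-type nitrogen and a saturated chain carbon. Among the measured compounds shown here, no measured step bears directly on this change. The step from compound 1 to compound 2 shows that a flat ring on this chain carbon is tolerated at least as well as a saturated one, and compound 2 and compound 3 show that adding a methyl to that ring does not move the number beyond the scatter. A second aromatic ring of a different size in the same place is therefore expected to give a step of a 1.5-fold higher number from compound 3 to compound 4 (0.16 log units; within the scatter), not beyond the scatter. Compound 4 is estimated at 45 nM, with a range from 15 nM to 150 nM.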

Compound 4, inhibition constant: 31.6 nM
Compound 4: the middle estimate sits 1.4-fold (0.15 log units) above what was measured; low and high end bracket the measured number.
By their numbers in this assay, from the lowest: compounds 3, 4 and 2 (each within the scatter of the next); then compound 1.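

In this assay, furan-2-yl stands in for 4-methylphenyl with no difference that can be told apart (a 1.0-fold higher number from compound 3 to compound 4 (0.01 log units; within the scatter)), and the same holds for the comparison with the 1-phenylethyl group (a 1.6-fold lower number from compound 2 to compound 4 (0.21 log units; within the scatter)). This place on the saturated chain carbon therefore accepts a five-membered aromatic ring with an oxygen as well as a six-membered ring of carbon only, although furan-2-yl has fewer heavy atoms and brings a hydrogen-bond acceptor. The 1-(furan-2-yl)ethyl group also stands clear of cyclohexyl (a 5.4-fold lower number from compound 1 to compound 4 (0.73 log units; beyond the scatter)), so compound 4 sits with compound 2 and compound 3 rather than with compound 1.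

Still open, as far as these compounds go, is how a ring carrying an amine or a carboxylic acid, or an ethyl group in place of the methyl on the chain carbon, would fare. No supporting measurement explains why these aromatic rings give such similar results.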